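A Cyclopentyl Urea in Place of the Phenyl Urea

This account rests on a few compounds, and the source may have more. Where it says the series, first, only, none or still open, it means among the compounds named here.

Among the compounds with values here, compound 1 `O=C(Nc1ccccc1)Nc1cccc(CNc2nccnc2Cl)c1` gives 15600 nM in a functional assay on HepG2 cells (Homo sapiens) for antiproliferative activity, read by MTT assay, with a stated time of 48 h (a higher number here means a weaker inhibitor, a lower number a stronger inhibitor), the highest of the two numbers measured so far. Compound 2 `CC(C)(C)c1ccc(NC(=O)Nc2cccc(CNc3nccnc3Cl)c2)cc1` gives 7550 nM in this assay, and the step of a 2.1-fold lower number from compound 1 to compound 2 (0.32 log units; beyond the scatter) came with tert-butyl in place of hydrogen on an aromatic carbon. Compound 3 `O=C(Nc1cccc(CNc2nccnc2Cl)c1)NC1CCCC1` differs from compound 1 by cyclopentyl in place of phenyl on an amide-type nitrogen. Within the data shown here, no measured step touches the urea substituent itself, so the single known step gives no guide to direction. For compound 3 the expected step is a 1.0-fold lower number from compound 1 to compound 3 (0.02 log units; within the scatter), nothing beyond the scatter. Compound 3 is therefore estimated at 15000 nM, within 5000 nM to 45000 nM.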

Compound 3, half-maximal inhibitory concentration: 18400 nM
Estimate against measurement, compound 3: 1.2-fold (0.09 log units) below, within the range that was stated.
By their numbers in this assay, from the lowest: compound 2; then compounds 1 and 3 (each within the scatter of the next).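

Putting cyclopentyl in place of phenyl on the amide-type nitrogen gives a 1.2-fold higher number from compound 1 to compound 3 (0.07 log units; within the scatter) in this assay. The earlier step altered only a hydrogen on an aromatic carbon, whereas this one replaces the whole aromatic ring with a non-aromatic one, and compound 3 stays level with compound 1. Nothing measured here accounts for this result.

As far as these compounds go, it remains open whether a cyclohexyl ring or a straight butyl chain on that nitrogen would also stay level. Also open, from the compounds shown here alone, is whether a tert-butyl group would lower the number on the cyclopentyl ring as it does on the phenyl ring.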